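Replacing a Ring Ether by a Small Amine on the Side Chain

The compounds below may be only part of what the source reports. "The series", "measured", "known", "first", "only" and "open" are said of these compounds alone.

Measured so far in a functional assay on the whole organism (strain Wistar albino) for inhibition, with Rattus norvegicus as the target, read by paw edema, with stated times of 30 min and 0.5 h, at a dose of 10 mg/kg by the oral route; a lower number here means less inhibition, a higher number more inhibition at the dose given (going by the name of the read-out):
compound 1 `COc1ccc(F)cc1-c1cccc(-c2nn(CCCC#N)c(=O)o2)c1` gives 29%
compound 2 `COc1ccc(F)cc1-c1cccc(-c2nn(CCCCF)c(=O)o2)c1` gives 36%
compound 3 `COc1ccc(F)cc1-c1cccc(-c2nn(CCOC3CCCCO3)c(=O)o2)c1` gives 16%

Compound 3 stands lowest of the three; its steps to the others are both beyond the scatter, a number 13 percentage points lower from compound 1 to compound 3 (beyond the scatter) and a number 20 percentage points lower from compound 2 to compound 3 (beyond the scatter). Compound 4 `COc1ccc(F)cc1-c1cccc(-c2nn(CCCN)c(=O)o2)c1` differs from compound 3 in one place: aminomethyl in place of (oxan-2-yl)oxy on a saturated chain carbon, two bonds along the chain from an aromatic nitrogen. The two measured steps that bear on this change both swap a small chain group for the (oxan-2-yl)oxy group at the same place, and both lowered the number. Going the other way, from the ring ether to a short open chain, the expectation is therefore a rise in this assay, estimated as a number 12 percentage points higher from compound 3 to compound 4 (beyond the scatter). Compound 4 is expected to give 28%, within a range from 14% to 42%.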

Compound 4, a percentage reported as inhibition, in the whole organism at one dose (the size of the read-out at that dose, not a potency): 29%
Beside the measured number, compound 4's estimate is 1 percentage points below it; low and high end bracket the measured number.
By their numbers in this assay, from the lowest: compound 3; then compounds 1, 4 and 2 (each within the scatter of the next).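

With the amine, the ring ether's low reading does not carry over to a small open chain in this assay: there is a number 13 percentage points higher from compound 3 to compound 4 (beyond the scatter). Against the other open chains the amine shows no change at the digits printed from compound 1 to compound 4 (within the scatter) and a number 7 percentage points lower from compound 2 to compound 4 (within the scatter), so among these four compounds only the ring ether stands apart, and a nitrile, a fluorine and an amine on the chain are not told apart. Nothing given here explains this. Still open, as far as these compounds go, is what a carboxylic acid or a dimethylamino group in place of the aminomethyl would give, and whether a longer chain carrying the amine reads the same.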